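The source may hold more compounds than are shown below. What is called first, only, known or untested is meant among the compounds shown, and "the series" means these compounds.

Measured so far in a functional assay on PC-3 cells (Homo sapiens) for inhibition, read by MTT assay, with a stated time of 72 h; on this read-out higher numbers stand for weaker inhibition and lower numbers for stronger inhibition:

Compound 1 `FC(F)(F)c1ccc(CSc2nc(N3CCN(c4ccccc4)CC3)cc(C(F)(F)F)n2)cc1` gives 42700 nM
Compound 2 `FC(F)(F)c1ccc(CSc2nc(N3CCN(c4ncccn4)CC3)cc(C(F)(F)F)n2)cc1` gives > 50000 nM, which is a limit
Compound 3 `Cc1csc(Sc2cc(C(F)(F)F)nc(SCc3ccc(C(F)(F)F)cc3)n2)n1` gives 12000 nM

Compound 3 at 12000 nM holds the lower of the two actual numbers. Compound 1 gives 42700 nM, and the gap between these two numbers lies beyond the scatter. Compound 2 is known only as a limit, > 50000 nM, and not as a number.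

Compound 4 `FC(F)(F)c1ccc(CSc2nc(SC3=NCCS3)cc(C(F)(F)F)n2)cc1` alters the group on the sulfur: a group of 5 heavy atoms (3 carbon, 1 nitrogen, 1 sulfur; one five-membered non-aromatic ring with 2 hetero atoms) in place of a group of 6 heavy atoms (4 carbon, 1 nitrogen, 1 sulfur; one five-membered aromatic ring with 2 hetero atoms), on a sulfur. For the measured compounds named here, the one measured step, an at least 1.1-fold higher number from compound 1 to compound 2 (0.06 log units; that floor lies within the scatter), rests on that limit and concerns a different change, pyrimidin-2-yl in place of phenyl on an amine nitrogen in a ring. It therefore gives little guidance, and no step beyond the scatter is expected in this assay, though a slightly higher number is expected rather than a lower one. The expected step is a 1.5-fold higher number from compound 3 to compound 4 (0.18 log units; within the scatter). For compound 4 the estimated value is 18000 nM, with an expected range from 7000 nM to 45000 nM.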

Compound 4, half-maximal inhibitory concentration: 40600 nM
For compound 4 the middle estimate is 2.3-fold (0.35 log units) below the measured one, and the stated range covers the measured number.
By their numbers in this assay, from the lowest: compound 3; then compounds 4 and 1 (each within the scatter of the next). At a limit, above all of these: compound 2.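

In this assay, the non-aromatic five-membered ring taking the place of 4-methyl-1,3-thiazol-2-yl on the sulfur gives a 3.4-fold higher number from compound 3 to compound 4 (0.53 log units; beyond the scatter), a modest step. It is the first step shown at this sulfur and the first shown beyond the scatter, so the group held there does change the read-out. Nothing measured here accounts for the step.

On these data alone, the two groups differ both in the methyl and in whether the ring is aromatic, and which of these carries the step stays open. A plain thiazol-2-yl or a phenyl on the same sulfur would help to separate them.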